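Replacing 4-methylphenyl with 3-(trifluoromethyl)phenyl in compound 3

A few compounds are considered here, and "the series" means these few. Any claim that something is new, unique, unknown or untested is made for them only; others in the source may bear on it.

Compound 1 `COc1ccc(-c2c(Nc3cc(OC)c(OC)c(OC)c3)c3ccccc3oc2=O)cc1` gives 77300 nM
Compound 2 `COc1ccc(-c2c(Nc3ccc(C)c(O)c3)c3ccccc3oc2=O)cc1` gives 10200 nM
Compound 3 `COc1ccc(-c2c(Nc3ccc(C)cc3)c3ccccc3oc2=O)cc1` gives 59400 nM

All three numbers come from a functional assay on HepG2 cells (Homo sapiens) for antiproliferative activity, read by MTT assay, with a stated time of 48 h (on this read-out lower numbers stand for stronger inhibition and higher numbers for weaker inhibition), and they place compound 3 within the scatter of compound 1, well apart from compound 2. Among the measured compounds shown here, the only measured step that reaches compound 3 is a 5.8-fold higher number from compound 2 to compound 3 (0.77 log units; beyond the scatter) and it concerns a hydroxy group, which neither compound 3 nor compound 4 carries. The next structure, compound 4 `COc1ccc(-c2c(Nc3cccc(C(F)(F)F)c3)c3ccccc3oc2=O)cc1`, keeps the shared core and changes one group: 3-(trifluoromethyl)phenyl in place of 4-methylphenyl on a nitrogen on an aromatic ring.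

For the measured compounds named here, no measured step tests a trifluoromethyl group, so the step from compound 2 gives only a rough idea of how far a change on this ring can move the number. Compound 1 also lacks the hydroxy group and gives 77300 nM in the same range as compound 3. No change beyond the scatter is therefore expected, and the estimate means a 1.3-fold lower number from compound 3 to compound 4 (0.12 log units; within the scatter) in this assay with wide uncertainty. The estimated value for compound 4 is 45000 nM (expected range 15000 nM to 110000 nM).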

Compound 4, half-maximal inhibitory concentration: 66400 nM
Compound 4: middle estimate off by 1.5-fold (0.17 log units), on the low side, within the range that was stated.
By their numbers in this assay, from the lowest: compound 2; then compounds 3, 4 and 1 (each within the scatter of the next).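

In this assay this is the only test shown of a trifluoromethyl group on the ring attached to this nitrogen, and the exchange gives a 1.1-fold higher number from compound 3 to compound 4 (0.05 log units; within the scatter), so the number stays in the same range as with 4-methylphenyl. Among the compounds shown here, putting 3-(trifluoromethyl)phenyl in place of 3-hydroxy-4-methylphenyl gives a 6.5-fold higher number from compound 2 to compound 4 (0.81 log units; beyond the scatter), so of compounds 2, 3 and 4 only compound 2, the one with a hydroxy group, stands apart with a lower number. No measurement is available that would explain these numbers.

The compounds shown leave open whether the lower number of compound 2 depends on the hydroxy group itself or would also appear with an amine or a carboxylic acid on this ring. They also leave open whether adding a hydroxy group to the ring of compound 4 would lower its number as well.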